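Side chain on the triple bond: methoxy to isopropyl

The source may hold more compounds than are shown below. What is called first, only, known or untested is meant among the compounds shown, and "the series" means these compounds.

In an ADME assay on NIH3T3 cells (Mus musculus) for cytotoxicity (a lower number here means that less compound is tolerated, a higher number that more compound is tolerated), compound 1 (`CN(C)CC#Cc1cc2ncnc(Nc3ccc(OCc4cccc(F)c4)c(Cl)c3)c2s1`) gives > 50 uM as a limit. Compound 2 (`Fc1cccc(COc2ccc(Nc3ncnc4cc(C#CCN5CCNCC5)sc34)cc2Cl)c1`) gives > 50 uM as a limit. Compound 3 (`COCC#Cc1cc2ncnc(Nc3ccc(OCc4cccc(F)c4)c(Cl)c3)c2s1`) gives > 50 uM as a limit, so it has no number of its own. The series stands together (the limit of > 50 uM in this assay, at which 3 of the 3 values shown sit) in these notes.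

Going by the values given here, compound 4 (`CC(C)CC#Cc1cc2ncnc(Nc3ccc(OCc4cccc(F)c4)c(Cl)c3)c2s1`) has isopropyl in place of methoxy on a saturated chain carbon bound to a triple-bonded carbon as its only change.

Two measured changes at this place bear on it (a step that the two limits leave unreadable from compound 1 to compound 3) and (a step that the two limits leave unreadable from compound 2 to compound 3) but give no size. The expected step in this assay is estimated as a number no higher from compound 3 to compound 4 (the limit leaves the size open) for now. Compound 4 is estimated at 50 uM with an expected range from 20 uM to 100 uM. Compound 4 is expected to give a limit again.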

Compound 4, half-maximal toxic concentration: > 50 uM
Compound 4: no number, only a limit; the forecaster's own chance of this, stated with the estimate: 75%; the middle value sits exactly at the limit.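

Compound 4 gives > 50 uM as a limit, so no step can be read among compound 1, compound 2, compound 3 and compound 4: the limit of > 50 uM in this assay, at which 4 of the 4 values shown sit.

In this assay the compounds shown leave open whether these side chains differ at all.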